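The compounds below may be only part of what the source reports. "The series", "measured", "known", "first", "only" and "open" are said of these compounds alone.

Compound 2, `COc1cc(CN(C)C(=O)c2nn(-c3ccc(F)cc3)c(OC[C@@H](O)C[C@@H](O)CC(=O)O)c2C(C)C)cc(OC)c1`, gives 43 nM in an assay on microsomes from liver for inhibition of 3-hydroxy-3-methylglutaryl-coenzyme A reductase (Rattus norvegicus) (a higher number here means a weaker inhibitor, a lower number a stronger inhibitor), the higher of the two numbers recorded so far. Within the data shown here, compound 1, `COc1ccc(CNC(=O)c2nn(-c3ccc(F)cc3)c(OC[C@@H](O)C[C@@H](O)CC(=O)O)c2C(C)C)cc1`, gives 12 nM in this assay, a lower value that lies beyond the scatter; compound 1 differs from compound 2 in more than one place, so no single step between them is counted. Compound 3, `Cc1cccc(CN(C)C(=O)c2nn(-c3ccc(F)cc3)c(OC[C@@H](O)C[C@@H](O)CC(=O)O)c2C(C)C)c1`, carries 3-methylphenyl in place of 3,5-dimethoxyphenyl on a saturated chain carbon bound to an amide-type nitrogen. Among the measured compounds shown here, with no measured pair isolating this change, the step of a 1.1-fold lower number from compound 2 to compound 3 (0.03 log units; within the scatter) is expected to stay within the scatter. Compound 3 is thus estimated at 40 nM, with a range from 12 nM to 130 nM.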

Compound 3, half-maximal inhibitory concentration: 37 nM
Beside the measured number, compound 3's estimate is 1.1-fold (0.03 log units) above it; the measured number falls inside the stated range.
By their numbers in this assay, from the lowest: compound 1; then compounds 3 and 2 (each within the scatter of the next).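

The 3,5-dimethoxyphenyl group on a saturated chain carbon bound to an amide-type nitrogen gives way to 3-methylphenyl with only a 1.2-fold lower number from compound 2 to compound 3 (0.07 log units; within the scatter) in this assay, so in this pair the ring's substituents can change without a step beyond the scatter. The larger step is methyl(3-methylbenzyl)amino in place of (4-methoxybenzyl)amino on a carbonyl carbon, a 3.1-fold higher number from compound 1 to compound 3 (0.49 log units; beyond the scatter). Nothing available explains either step.

The compounds shown leave open how much of that larger step belongs to the methyl on the nitrogen and how much to the ring's substitution. Also open, on these data alone, is how a chlorine or a hydroxyl on this ring would read.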